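Compound 2 to compound 3: an amide group exchanged

The source may report more compounds than this note shows. Statements on the series, on what has been measured and on what is new or still open speak of the compounds shown alone.

In a functional assay on KB cells (Homo sapiens) for antiproliferative activity, read by sulforhodamine B assay, with a stated time of 3 days (a higher number here means a weaker inhibitor of growth, a lower number a stronger inhibitor of growth), compound 1 `COc1ccc(NC(=O)c2cccc(Nc3ncc(F)c(Nc4ccc(F)cc4)n3)c2)cc1` gives > 10000 nM, which is a limit of the assay and not a number. Among the measured compounds shown here, compound 2 `O=C(c1cccc(Nc2ncc(F)c(Nc3ccc(F)cc3)n2)c1)N1CCCCC1` gives 14800 nM, the only actual number so far. Compound 3 `CN1CCC(C(=O)Nc2cccc(Nc3ncc(F)c(Nc4ccc(F)cc4)n3)c2)CC1` differs from it as follows: ((1-methylpiperidin-4-yl)carbonyl)amino in place of (piperidin-1-yl)carbonyl on an aromatic carbon. For the measured compounds named here, the one measured step, a step that the limit leaves unreadable from compound 1 to compound 2, has no readable size, so it offers no basis for expecting a shift in either direction. The estimated step is a 1.5-fold lower number from compound 2 to compound 3 (0.17 log units; within the scatter), which means no change beyond the scatter is expected in this assay. Compound 3 is expected at 10000 nM, within an estimated range of 3000 nM to 30000 nM.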

Compound 3, concentration for 50% growth inhibition: 1700 nM
Beside the measured number, compound 3's estimate is 5.9-fold (0.77 log units) above it; the whole stated range lies above it.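

The exchange of (piperidin-1-yl)carbonyl for ((1-methylpiperidin-4-yl)carbonyl)amino on this aromatic carbon gives, in this assay, the first readable size at this position: an 8.7-fold lower number from compound 2 to compound 3 (0.94 log units; beyond the scatter). Set against the (4-methoxyphenyl)carbamoyl group, the same entering group gives an at least 5.8-fold lower number from compound 1 to compound 3 (0.76 log units; beyond the scatter). The value of compound 1 is a limit of the assay and not a number, which leaves its step to compound 2 unreadable: the limit of > 10000 nM in this assay, at which 1 of the 3 values shown sits.

The compounds shown do not separate the share of the amide hydrogen from that of the methyl-bearing ring nitrogen in this step. As far as these compounds go, how a morpholine or an open-chain dimethylamino group would read in place of the 1-methylpiperidin-4-yl ring also stays open.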